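Swapping fluoro for cyano on the amide aryl ring

The compounds below may be only part of what the source reports. "The series", "measured", "known", "first", "only" and "open" are said of these compounds alone.

Among the compounds with values here, compound 1 `O=C(Nc1cccc(-c2oc3cc(-c4ccc(F)cc4)ccc3c(=O)c2O)c1)c1ccc(F)cc1` is the stronger-looking of the two measured members of this set, though only by a hair: in a functional assay on GTL 16 cells for antiproliferative activity against GTL 16 cell line (Homo sapiens), read by CCK-8 assay, with a stated time of 72 h (on this read-out lower numbers stand for stronger inhibition and higher numbers for weaker inhibition), compound 1 gives 14600 nM, the lowest of the two numbers. Compound 2 `COc1ccc(C(=O)Nc2cccc(-c3oc4cc(-c5ccc(F)cc5)ccc4c(=O)c3O)c2)c(F)c1` carries 2-fluoro-4-methoxyphenyl in place of 4-fluorophenyl on the carbonyl carbon, and in this assay compound 2 gives 15300 nM. The step of a 1.0-fold higher number from compound 1 to compound 2 (0.02 log units; within the scatter) thus shows that reworking this aryl ring left the read-out essentially unchanged.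

Compound 3 `N#Cc1ccc(C(=O)Nc2cccc(-c3oc4cc(-c5ccc(F)cc5)ccc4c(=O)c3O)c2)cc1` has not been measured. It differs from compound 1 in one place: cyano in place of fluoro on an aromatic carbon. Within the data shown here, the only step at hand, from compound 1 to compound 2, altered the same aryl ring and stayed within the scatter, so it offers no reason to expect a shift beyond the scatter here either. The expected step is therefore a 1.1-fold lower number from compound 1 to compound 3 (0.05 log units; within the scatter). Compound 3 is estimated to give 13000 nM in this assay, with a range from 5000 nM to 35000 nM.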

Compound 3, half-maximal inhibitory concentration: 31800 nM
The estimate for compound 3 lay 2.4-fold (0.39 log units) below the measured number, within the range that was stated.
By their numbers in this assay, from the lowest: compounds 1 and 2 (each within the scatter of the next); then compound 3.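

In this assay, within the data shown here, this is the first change on the amide aryl ring to move the number beyond the scatter, and the shift is modest: a 2.2-fold higher number from compound 1 to compound 3 (0.34 log units; beyond the scatter), and a 2.1-fold higher number from compound 2 to compound 3 (0.32 log units; beyond the scatter). The earlier swap of 4-fluorophenyl for 2-fluoro-4-methoxyphenyl left the read-out unchanged within the scatter, so the ring does not accept every change equally: here, cyano in place of fluoro, para to a large group, gives weaker inhibition. Nothing available explains this difference.

The three compounds cannot show whether the loss is specific to cyano or would also appear with another group at this place, such as a carboxylic acid, an amine or a simple methyl. They also leave open whether cyano would give a similar step elsewhere on the same ring, or whether the same change would have the same effect with a different group in place of the 4-fluorophenyl on the shared core.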